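From Methoxycarbonyl to Ethoxycarbonyl in Compound 3

The compounds below may be only part of what the source reports. "The series", "measured", "known", "first", "only" and "open" are said of these compounds alone.

Compound 2 `COC(=O)C1=C(C)NC(C)=C(C(=O)OC)C1c1ccc(-c2cc(=O)cc(C)o2)cc1` gives 17800 nM in an assay on isolated protein (strain albino) for inhibition of Voltage-dependent L-type calcium channel subunit alpha-1C (Cavia porcellus) (on this read-out lower numbers stand for stronger inhibition and higher numbers for weaker inhibition), the highest of the two numbers recorded. Compound 1 `COC(=O)C1=C(C)NC(C)=C(C(=O)OC)C1c1ccc(-c2cc(=O)cc(-c3ccccc3)o2)cc1` gives 4710 nM in this assay. Among the measured compounds shown here, the only measured step, a 3.8-fold higher number from compound 1 to compound 2 (0.58 log units; beyond the scatter), comes from a methyl in place of phenyl on an aromatic carbon and does not touch the position changed here. Compound 3 `CCOC(=O)C1=C(C)NC(C)=C(C(=O)OC)C1c1ccc(-c2cc(=O)cc(C)o2)cc1` differs from compound 2 by methyl in place of hydrogen on a saturated chain carbon bound to an oxygen next to a carbonyl group, read one bond further out as methoxycarbonyl to ethoxycarbonyl. For the measured compounds named here, with no step bearing on it, the expected change is none beyond the scatter, a 1.3-fold lower number from compound 2 to compound 3 (0.10 log units; within the scatter). Compound 3 is expected to give about 14000 nM, within 5000 nM to 40000 nM.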

Compound 3, half-maximal inhibitory concentration: 86100 nM
Compound 3: middle estimate off by 6.2-fold (0.79 log units), on the low side, and the stated range ends below it.
By their numbers in this assay, from the lowest: compound 1; then compound 2; then compound 3.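

In this assay, moving from methoxycarbonyl to ethoxycarbonyl is not a neutral change: the step reads a 4.8-fold higher number from compound 2 to compound 3 (0.68 log units; beyond the scatter) and so goes toward weaker inhibition. Among the compounds shown here, this shows that the ester position responds to one added methyl, whereas the earlier compounds varied only the group on an aromatic carbon. No available evidence explains the shift. From the compounds shown here alone, whether a longer chain or a carboxylic acid at this position would move the number further remains open. So does whether ethoxycarbonyl would act the same way with the phenyl group of compound 1.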